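A few compounds are considered here, and "the series" means these few. Any claim that something is new, unique, unknown or untested is made for them only; others in the source may bear on it.

Within the data shown here, compound 3 `O=S(=O)(NCCCNCc1ccccc1Cl)c1cc(C(F)(F)F)cc(C(F)(F)F)c1` carries the 2-chlorobenzyl group on the shared core, and in a functional assay on HPAC cells (Homo sapiens) for inhibition, read by MTT assay, with a stated time of 72 h (a higher number here means a weaker inhibitor of growth, a lower number a stronger inhibitor of growth), compound 3 gives 10000 nM, the highest of the three numbers measured so far. Its neighbours are compound 1 `O=S(=O)(NCCCNCc1ccc(Cl)cc1)c1cc(C(F)(F)F)cc(C(F)(F)F)c1`, which in this assay gives 2800 nM, and compound 2 `O=S(=O)(NCCCNCc1cccc(Cl)c1)c1cc(C(F)(F)F)cc(C(F)(F)F)c1`, which gives 2700 nM. The measured steps are all moves of the chloro around the ring: a 1.0-fold lower number from compound 1 to compound 2 (0.02 log units; within the scatter), while a 3.6-fold higher number from compound 1 to compound 3 (0.55 log units; beyond the scatter) and a 3.7-fold higher number from compound 2 to compound 3 (0.57 log units; beyond the scatter).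

Compound 4 `COc1ccccc1CNCCCNS(=O)(=O)c1cc(C(F)(F)F)cc(C(F)(F)F)c1` differs from compound 3 by methoxy in place of chloro on an aromatic carbon. Among the measured compounds shown here, no measured step exchanges chloro for another group; the steps from compound 1 and compound 2 to compound 3 only show that the 2-chlorobenzyl arrangement sits at the weak end of this small set, and they say nothing about what a methoxy does in that same place. Compound 4 is therefore expected to stay close to compound 3, with no change at the digits printed from compound 3 to compound 4 (within the scatter) expected to lie within the scatter. The estimate for compound 4 in this assay is 10000 nM, with a range from 4000 nM to 25000 nM.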

Compound 4, concentration for 50% growth inhibition: 2400 nM
For compound 4 the middle estimate is 4.2-fold (0.62 log units) above the measured one, outside the stated range (below it).
By their numbers in this assay, from the lowest: compounds 4, 2 and 1 (each within the scatter of the next); then compound 3.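

In this assay the ring place carrying the chloro in the 2-chlorobenzyl group now proves responsive to the group it holds, with a 4.2-fold lower number from compound 3 to compound 4 (0.62 log units; beyond the scatter) on moving to the 2-methoxybenzyl group, so the high number of compound 3 does not follow from having a group at this place alone. The 2-methoxybenzyl group also stands level with the chloro groups on the other ring places, with a 1.1-fold lower number from compound 2 to compound 4 (0.05 log units; within the scatter) and a 1.2-fold lower number from compound 1 to compound 4 (0.07 log units; within the scatter) both lying within the scatter. Nothing measured here accounts for the gap between chloro and methoxy at this place.

The compounds shown leave open whether methoxy in place of chloro on the 3-chlorophenyl or 4-chlorophenyl group would shift the number at all. They also leave open what a fluoro, a hydroxy or an amine on the same aromatic carbon would give.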